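This account rests on a few compounds, and the source may have more. Where it says the series, first, only, none or still open, it means among the compounds named here.

Of the compounds shown here, three sharing one core have already been measured. Compound 1 `CCN(C(=O)OC)c1c(N)nc(-c2nn(Cc3ccccc3F)c3ncccc23)nc1N` gives 0.2 uM in an assay on cells for activation of Guanylate cyclase soluble subunit alpha-1 (Rattus norvegicus), read by cGMP accumulation and immunoassay, with a stated time of 10 min; on this read-out lower numbers stand for an effect already at smaller amounts and higher numbers for an effect only at larger amounts of compound. Compound 2 `COC(=O)N(Cc1ccc(F)cc1)c1c(N)nc(-c2nn(Cc3ccccc3F)c3ncccc23)nc1N` gives 0.7 uM in this assay, and the step of a 3.5-fold higher number from compound 1 to compound 2 (0.54 log units; beyond the scatter) is a modest loss. Compound 3 `Nc1nc(-c2nn(Cc3ccccc3F)c3ncccc23)nc(N)c1NC(=O)OC1CCC1` gives 0.2 uM in this assay, and the step of no change at the digits printed from compound 1 to compound 3 (within the scatter) shows that exchanging the whole group on that aromatic carbon left the number where it was. Compound 3 thus stands level with compound 1 and shares the lowest number of the three, while compound 2 sits higher.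

Compound 4 `Nc1nc(-c2nn(Cc3ccccc3F)c3ncccc23)nc(N)c1N1CCOC1=O` has not yet been measured. It differs from compound 3 in one place: 2-oxo-1,3-oxazolidin-3-yl in place of (cyclobutyloxycarbonyl)amino on an aromatic carbon. The entering group is smaller than the one leaving, and it closes the chain into a ring.

Among the compounds with values here, two measured steps bear on this. The step from compound 1 to compound 3 was within the scatter despite a sizeable rearrangement of this group, whereas the step from compound 1 to compound 2 was a modest loss when a larger group was added. The new group in compound 4 is not larger, so a step in this assay near the scatter, or a small loss at most, is expected: a 1.5-fold higher number from compound 3 to compound 4 (0.18 log units; within the scatter). Compound 4 is therefore estimated at 0.3 uM, with a range from 0.1 uM to 1 uM.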

Compound 4, minimum effective concentration: 0.3 uM
Beside the measured number, compound 4's estimate shows no gap at the digits printed; measured number inside the range.
By their numbers in this assay, from the lowest: compounds 1, 3 and 4 (each within the scatter of the next); then compound 2.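

In this assay, the 2-oxo-1,3-oxazolidin-3-yl ring gives a 1.5-fold higher number from compound 3 to compound 4 (0.18 log units; within the scatter) and a 1.5-fold higher number from compound 1 to compound 4 (0.18 log units; within the scatter), so both steps stay small enough to be ordinary variation between repeated measurements. Compounds 1 and 3 had shown this aromatic carbon carrying only open carbamate groups, one with the amide hydrogen and one without it, whereas compound 4 ties the nitrogen and the oxygen of such a group into a five-membered ring and still reads level with both within the scatter, which shows that an open chain on this nitrogen is not required for activity at this level in this assay. No measurement is available that explains why closing the ring leaves the number within the scatter.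

The compounds shown leave open whether the oxygen in the new ring or the carbonyl matters, which a pyrrolidin-2-one or a pyrrolidine at the same place could test. They also leave open how far ring size can go, as a six-membered 2-oxo-1,3-oxazinan-3-yl ring or a simple amine such as dimethylamino on this aromatic carbon would show.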